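The source may report more compounds than this note shows. Statements on the series, on what has been measured and on what is new or still open speak of the compounds shown alone.

Working notes on the coumarin amide series. Compound 1 `CC(=O)Oc1ccc(C(=O)Nc2cc3ccc(OCCC4CCCCN4)c(C)c3oc2=O)cc1CC=C(C)C` and compound 2 `CCNCCCOc1ccc2cc(NC(=O)c3ccc(O)c(CC=C(C)C)c3)c(=O)oc2c1C` have both been measured in a functional assay on SK-BR-3 cells (Homo sapiens) for antiproliferative activity; on this read-out lower numbers stand for stronger inhibition and higher numbers for weaker inhibition. In this assay compound 1 gives 640 nM, and compound 2 gives 720 nM; the two numbers lie within the usual scatter of each other, so neither can be set apart from the other on these data. Compound 3 `CC(C)=CCc1cc(C(=O)Nc2cc3ccc(OCCCN(C)C(C)(C)C)c(C)c3oc2=O)ccc1O` has not been measured. It differs from compound 2 in one place: methyl(tert-butyl)amino in place of ethylamino on a saturated chain carbon, three bonds along the chain from an oxygen on an aromatic ring. For the measured compounds named here, no pair of measured compounds in the set differs in only this place, so there is no measured step of the same kind to lean on. On the basis of compound 2 alone, the amine change is expected to move the number little, and the estimated step of a 1.2-fold higher number from compound 2 to compound 3 (0.07 log units; within the scatter) is expected to stay within the scatter, if anything toward a slightly higher number. Compound 3 is therefore estimated at about 850 nM, with a range of 350 nM to 2000 nM.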

Compound 3, half-maximal inhibitory concentration: 880 nM
The estimate for compound 3 lay 1.0-fold (0.02 log units) below the measured number, and the stated range covers the measured number.
By their numbers in this assay, from the lowest: compounds 1, 2 and 3 (each within the scatter of the next).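

In this assay, for the compounds shown here, the swap of ethylamino for methyl(tert-butyl)amino on a saturated chain carbon, three bonds along the chain from an oxygen on an aromatic ring, gives a 1.2-fold higher number from compound 2 to compound 3 (0.09 log units; within the scatter) and so cannot be told from no step at all. This position therefore carries 6 heavy atoms in place of 3, and 0 hydrogen-bond donors in place of 1, without a difference beyond the scatter in this one pair. Nothing available explains this outcome.

Still open, from the compounds shown here alone, is whether the number would hold with a morpholine or a carboxylic acid at the chain end, or with a longer chain. A single pair also leaves open whether the same swap would give a similar step on other compounds of the series.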